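A Methoxyphenyl in Place of a Trichlorophenyl Ring

The compounds below may be only part of what the source reports. "The series", "measured", "known", "first", "only" and "open" are said of these compounds alone.

Of the compounds shown here, two sharing a common core have been tested in a functional assay on DU-145 cells (Homo sapiens) for inhibition, read by trypan blue exclusion, with a stated time of 96 h; a higher number here means a weaker inhibitor of growth, a lower number a stronger inhibitor of growth. Compound 1 `Cc1ccc(S/C(=C/c2cc(Cl)cc(Cl)c2Cl)C(=O)c2ccc(Cl)cc2)cc1` gives 50000 nM in this assay. Compound 2 `O=C(/C(=C\c1ccc(Oc2ccccc2)cc1)Sc1ccc(Br)cc1)c1ccc(Br)cc1` gives 50000 nM in this assay. On these numbers compound 1 stands level with compound 2: the two values agree at the digits recorded, with no difference beyond the scatter.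

Compound 3 `COc1ccc(/C=C(/Sc2ccc(C)cc2)C(=O)c2ccc(Cl)cc2)cc1` has not yet been measured in this assay. It differs from compound 1 in one place: 4-methoxyphenyl in place of 2,3,5-trichlorophenyl on a double-bonded chain carbon bound to a double-bonded chain carbon. Among the measured compounds shown here, no measured pair tracks an exchange of this kind, so the size of its effect is unknown. Because compound 1 gives 50000 nM and compound 2 gives 50000 nM without separation, the expectation is a step that stays small or within the scatter. Compound 3 is therefore expected to give about 40000 nM in this assay, within a range from 10000 nM to 50000 nM. The implied step a 1.3-fold lower number from compound 1 to compound 3 (0.10 log units; within the scatter) is estimated to be modest.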

Compound 3, concentration for 50% growth inhibition: 1000 nM
For compound 3 the middle estimate is 40-fold (1.60 log units) above the measured one; the measured number lies below the stated range.
By their numbers in this assay, from the lowest: compound 3; then compounds 1 and 2 (each within the scatter of the next).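

The exchange of 2,3,5-trichlorophenyl for 4-methoxyphenyl on a double-bonded chain carbon bound to a double-bonded chain carbon brings a 50-fold lower number from compound 1 to compound 3 (1.70 log units; beyond the scatter) in this assay, so the group at this position can strongly change the reading. Compounds 1 and 2 differ from each other in more than one place, so their level values could not show the effect of this position alone. The exchange removes the chlorine atoms and brings in an oxygen atom, and no measurement at hand tells which part of the change accounts for the step.

The compounds shown leave open whether the step comes from gaining the methoxy group, from losing the chlorine atoms, or from both. A plain phenyl or a 4-hydroxyphenyl group at this position could help separate these possibilities.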